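A few compounds are considered here, and "the series" means these few. Any claim that something is new, unique, unknown or untested is made for them only; others in the source may bear on it.

The study centres on a functional assay on LOX IMVI cells (Homo sapiens) for inhibition, read by sulforhodamine B assay, with a stated time of 48 h (on this read-out lower numbers stand for stronger inhibition of growth and higher numbers for weaker inhibition of growth), in which three compounds sharing one core have so far been measured. Compound 1, `CCOC(=O)[C@H](CCC(=O)O)NC(=O)c1ccc(Sc2nc3cc(N)cc(N)c3nc2-c2ccccc2)cc1`, gives 8510 nM in this assay. Compound 3, `COc1cc(CNc2nc3cc(N)cc(N)c3nc2-c2ccccc2)cc(OC)c1OC`, gives 10500 nM. Compound 2, `Nc1cc(N)c2nc(-c3ccccc3)c(Sc3ccc(F)cc3)nc2c1`, gives 40700 nM, the highest of the three numbers: compound 3 stands nearest below it and compound 1 furthest below it, and both of those gaps lie beyond the usual scatter, so compound 2 shows the weakest growth inhibition of the three. Going by the values given here, no pair of these measured compounds differs in a single place, so no measured step is available to lean on.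

The piece now turns to compound 4, `Nc1cc(N)c2nc(-c3ccccc3)c(Sc3ccc(Cl)c(Cl)c3)nc2c1`, which is not yet measured. It departs from compound 2 by one change, (3,4-dichlorophenyl in place of 4-fluorophenyl on a sulfur). With no measured step of this kind in the set, the expectation can rest only on compound 2 and its value of 40700 nM. For compound 4 a step from compound 2 of modest size is expected in this assay, estimated as a 1.6-fold lower number from compound 2 to compound 4 (0.21 log units; within the scatter), pointing toward a lower number but not far beyond the scatter. Compound 4 is therefore estimated at 25000 nM, with a range from 8000 nM to 80000 nM.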

Compound 4, concentration for total growth inhibition: 24500 nM
For compound 4 the middle estimate is 1.0-fold (0.01 log units) above the measured one; measured number inside the range.
By their numbers in this assay, from the lowest: compounds 1 and 3 (each within the scatter of the next); then compounds 4 and 2 (each within the scatter of the next).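

In this assay the set now holds its first measured step at this place, and a 1.7-fold lower number from compound 2 to compound 4 (0.22 log units; within the scatter) is what it shows for 3,4-dichlorophenyl in place of 4-fluorophenyl on a sulfur. The two halogen-bearing groups therefore cannot be told apart on this read-out, so the position accepts this exchange of one aryl group for another without a change that stands clear of repeated-measurement noise, and compound 4 stays in the same range as compound 2. No measurement accompanies the result that could say anything about why the two groups read alike.

The compounds shown leave open how a plain phenyl, a phenyl carrying a nitrile or a methoxy group, or a short alkyl chain would read on this same sulfur, and so whether the halogens matter here at all. They also leave open whether a larger step can be reached at this position, since a single exchange between two halogenated phenyl groups samples only a narrow part of what the sulfur could carry.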